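From methyl to fluoro: what compound 4 may show

The source may hold more compounds than are shown below. What is called first, only, known or untested is meant among the compounds shown, and "the series" means these compounds.

Compound 1 `O=c1cc(-c2ccccc2)oc2cc(OCCCCNc3nc4ccccc4s3)cc(O)c12`: 8.57 ug/mL
Compound 2 `Cc1ccc2nc(NCCCCOc3cc(O)c4c(=O)cc(-c5ccccc5)oc4c3)sc2c1`: 8.79 ug/mL
Compound 3 `O=c1cc(-c2ccccc2)oc2cc(OCCCCNc3nc4ccc(Cl)cc4s3)cc(O)c12`: 4.16 ug/mL

All three were measured in a physicochemical assay, read by spectrophotometry, with a stated time of 10 min; a higher number here means a weaker inhibitor, a lower number a stronger inhibitor. Compound 2 sits at the high end of these numbers, and its nearest neighbour shows a 1.0-fold higher number from compound 1 to compound 2 (0.01 log units; within the scatter). The furthest shows a 2.1-fold lower number from compound 2 to compound 3 (0.32 log units; beyond the scatter). Compound 4 `O=c1cc(-c2ccccc2)oc2cc(OCCCCNc3nc4ccc(F)cc4s3)cc(O)c12` has fluoro in place of methyl on an aromatic carbon. Among the compounds with values here, no fluoro compound has been measured, so the closest guide is chloro, which gave the step above and a 2.1-fold lower number from compound 1 to compound 3 (0.31 log units; beyond the scatter). Methyl against hydrogen gave nothing beyond the scatter. A lower number is therefore expected, though by less than chloro gave, and it may stay within the scatter. The expected step is a 1.5-fold lower number from compound 2 to compound 4 (0.17 log units; within the scatter). Compound 4 is estimated at 6 ug/mL, with an expected range of 3.5 ug/mL to 10 ug/mL.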

Compound 4, half-maximal inhibitory concentration: 5.25 ug/mL
Compound 4: the middle estimate sits 1.1-fold (0.06 log units) above what was measured; the range from low to high includes it.
By their numbers in this assay, from the lowest: compounds 3, 4, 1 and 2 (each within the scatter of the next, the first and the last beyond it).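

Fluoro on this aromatic carbon cannot be told apart from hydrogen (a 1.6-fold lower number from compound 1 to compound 4 (0.21 log units; within the scatter)), from methyl (a 1.7-fold lower number from compound 2 to compound 4 (0.22 log units; within the scatter)) or from chloro (a 1.3-fold higher number from compound 3 to compound 4 (0.10 log units; within the scatter)). Chloro alone had stepped beyond the scatter from hydrogen and methyl, yet fluoro lies within the scatter of all three, so the compounds now form a continuous run rather than two separate levels. From the compounds shown here alone, whether a methoxy or trifluoromethyl group here would step clearly beyond the scatter remains open. Nothing measured here explains these results.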